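From cyclohexylmethoxy to butoxy: working notes on the series

The compounds below may be only part of what the source reports. "The series", "measured", "known", "first", "only" and "open" are said of these compounds alone.

Measured so far in a functional assay on NUGC-3 cells (Homo sapiens) for antiproliferative activity, read by sulforhodamine B assay; a lower number here means a stronger inhibitor of growth, a higher number a weaker inhibitor of growth
- compound 1 `CC(C)CCCOc1cccc(O)c1C(=O)/C=C/c1ccc(O)cc1` gives 3520 nM
- compound 2 `CC(C)(C)CCOc1cccc(O)c1C(=O)/C=C/c1ccc(O)cc1` gives 3300 nM
- compound 3 `O=C(/C=C/c1ccc(O)cc1)c1c(O)cccc1OCC1CCCCC1` gives > 30000 nM (a limit, not a number)

Compound 3 stands at the limit of > 30000 nM in this assay, at which 1 of the 3 values shown sits, so it offers only a limit as a starting point. The change to compound 4 `CCCCOc1cccc(O)c1C(=O)/C=C/c1ccc(O)cc1` puts propyl in place of cyclohexyl on a saturated chain carbon bound to an oxygen on an aromatic ring. The same difference reads cyclohexylmethoxy to butoxy.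

Among the measured compounds shown here, three measured steps bear on this. Between the two open chains the change is a 1.1-fold lower number from compound 1 to compound 2 (0.03 log units; within the scatter). Cyclohexyl in place of the open chains gives an at least 8.5-fold higher number from compound 1 to compound 3 (0.93 log units; beyond the scatter) and an at least 9.0-fold higher number from compound 2 to compound 3 (0.95 log units; beyond the scatter). For the measured compounds named here, removing the ring should therefore reverse much of that loss in this assay, although no measured compound carries the butyl chain itself. The expected change is an at least 6.0-fold lower number from compound 3 to compound 4 (0.77 log units; beyond the scatter), towards a lower number. For compound 4 the estimated value is 5000 nM, with an expected range from 2000 nM to 15000 nM.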

Compound 4, concentration for 50% growth inhibition: > 30000 nM
Compound 4 ended at the assay's limit; the forecaster's own chance of this, stated with the estimate: 10%; middle value at least 6.0-fold (0.77 log units) away from the limit.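

In this assay compound 4 gives > 30000 nM, which is a limit and not a number, and the step from compound 3, also at a limit, cannot be read. Removing the ring therefore does not by itself restore a measurable number, and the butyl chain falls well short of the chains ending in isopropyl or tert-butyl, with an at least 9.0-fold higher number from compound 2 to compound 4 (0.95 log units; beyond the scatter) and an at least 8.5-fold higher number from compound 1 to compound 4 (0.93 log units; beyond the scatter). The loss at this position is thus not specific to cyclohexylmethoxy, and among the compounds shown only compound 1 and compound 2 give a number rather than a limit: the limit of > 30000 nM in this assay, at which 2 of the 4 values shown sit.

From the compounds shown here alone, it remains open whether chain length or the branching at the chain end separates compound 1 and compound 2 from compound 4. An unbranched hexyl chain would help to tell these two apart.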